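Moving the ring nitrogen in a pyridyl amide

A few compounds are considered here, and "the series" means these few. Any claim that something is new, unique, unknown or untested is made for them only; others in the source may bear on it.

Three amides sharing one core have been tested in a functional assay on the whole organism (strain Swiss Albino) for inhibition, with Mus musculus as the target, in the writhing test, with a stated time of 1 h, at a dose of 100 mg/kg by the oral route; on this read-out higher numbers stand for more inhibition at the one dose given (going by the name of the read-out) and lower numbers for less inhibition. Compound 1 `COc1cc2c(cc1OC)C(CC(=O)Nc1ccccc1C)CC2` gives 30%. Compound 2 `COc1cc2c(cc1OC)C(CC(=O)Nc1ccc(C)cc1)CC2` gives 41.4%, and the step of a number 11.4 percentage points higher from compound 1 to compound 2 (beyond the scatter) is modest. Compound 3 `COc1cc2c(cc1OC)C(CC(=O)Nc1cccnc1)CC2` gives 70.7%, which is the highest of the three numbers; the step of a number 40.7 percentage points higher from compound 1 to compound 3 (beyond the scatter) is large and the step of a number 29.3 percentage points higher from compound 2 to compound 3 (beyond the scatter) is modest, both beyond the scatter, so compound 3 stands clearly at the top.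

Compound 4 `COc1cc2c(cc1OC)C(CC(=O)Nc1ccncc1)CC2` is the untested partner. The change is pyridin-4-yl in place of pyridin-3-yl on an amide-type nitrogen. For the measured compounds named here, no measured step exchanges one pyridyl for another, so the bearing of the earlier steps is indirect: the two steps into compound 3 show that a pyridyl here gave higher inhibition than either methylphenyl, while the step from compound 1 to compound 2 shows that shifting a group around the ring can move the number by a modest amount. The step of a number 10.7 percentage points lower from compound 3 to compound 4 (beyond the scatter) is therefore expected to be small, possibly within the scatter, with some risk of a drop. Compound 4 is estimated at 60%, in a range from 40% to 80%.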

Compound 4, a percentage reported as inhibition, in the whole organism at one dose (the size of the read-out at that dose, not a potency): 60.1%
The estimate for compound 4 lay 0.1 percentage points below the measured number; measured number inside the range.
By their numbers in this assay, from the lowest: compound 1; then compound 2; then compound 4; then compound 3.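

Exchanging pyridin-3-yl for pyridin-4-yl keeps the same atoms and changes only where the ring nitrogen sits, yet the number falls (a number 10.6 percentage points lower from compound 3 to compound 4 (beyond the scatter)), so on this amide nitrogen the place of the ring nitrogen matters as well as its presence. The pyridin-4-yl amide still scores above both methylphenyl amides (a number 18.7 percentage points higher from compound 2 to compound 4 (beyond the scatter); a number 30.1 percentage points higher from compound 1 to compound 4 (beyond the scatter)), which means that both pyridyl amides now stand above both methylphenyl amides in this assay. No measurement shown here offers an explanation for the gap between the two pyridyl amides.

On these data alone, it remains open how a pyridin-2-yl group on the same nitrogen would score, or whether a methyl group or an amine on the pyridin-3-yl ring would keep the inhibition. A longer chain between the shared core and the carbonyl is also unexplored among these compounds.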